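Methoxy for Fluoro on the Benzyl Arm of Compound 2

The compounds below may be only part of what the source reports. "The series", "measured", "known", "first", "only" and "open" are said of these compounds alone.

Two close relatives of a shared core have been measured in a functional assay on SN12C cells (Homo sapiens) for inhibition, read by sulforhodamine B assay, with a stated time of 48 h; a higher number here means that more compound is tolerated, a lower number that less compound is tolerated. Compound 1 `Nc1cc(N)c2nc(-c3ccccc3)c(NCc3ccc(Cl)c(Cl)c3)nc2c1` gives 87100 nM, and compound 2 `Nc1cc(N)c2nc(-c3ccccc3)c(NCc3ccc(F)cc3)nc2c1` gives 64600 nM. Among the measured compounds shown here, the only measured step, a 1.3-fold lower number from compound 1 to compound 2 (0.13 log units; within the scatter), lies within the scatter, so compound 2 stands lowest of the two numbers only nominally, with compound 1 within the scatter of it. The next step leads to compound 3 `COc1ccc(CNc2nc3cc(N)cc(N)c3nc2-c2ccccc2)cc1`. Its change from compound 2 is methoxy in place of fluoro on an aromatic carbon. For the measured compounds named here, no measured step covers this exchange; the one step in hand, from a 3,4-dichlorophenyl to a 4-fluorophenyl, moved the number hardly at all, so no change beyond the scatter is expected in this assay for compound 3. The expected step is a 1.1-fold lower number from compound 2 to compound 3 (0.03 log units; within the scatter). Compound 3 is therefore estimated at 60000 nM, with a range from 25000 nM to 150000 nM.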

Compound 3, concentration lethal to 50% of the cells: 69200 nM
Estimate against measurement, compound 3: 1.2-fold (0.06 log units) below; the range from low to high includes it.
By their numbers in this assay, from the lowest: compounds 2, 3 and 1 (each within the scatter of the next).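

In this assay, among the compounds shown here, methoxy in place of fluoro on this aromatic carbon gives a 1.1-fold higher number from compound 2 to compound 3 (0.03 log units; within the scatter) and is the first direct reading of a change at this one atom, with the rest of compound 2 left as it stands. The step from the 3,4-dichlorophenyl arm gives a 1.3-fold lower number from compound 1 to compound 3 (0.10 log units; within the scatter), so the 4-fluorophenyl, 4-methoxyphenyl and 3,4-dichlorophenyl arms now all lie within the scatter of one another, even though methoxy carries a hydrogen-bond acceptor that fluoro does not. Nothing at hand gives a reason for this flat reading.

The compounds shown leave open whether any group at this place, such as an amine or a carboxylic acid, would move the number beyond the scatter. They also leave open what a longer chain carrying this ring would do, and what replacing the phenyl on the shared core would do.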